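From 3-fluorophenyl to 3-hydroxyphenyl: expected half-life

A few compounds are considered here, and "the series" means these few. Any claim that something is new, unique, unknown or untested is made for them only; others in the source may bear on it.

In an ADME assay on microsomes from liver (Mus musculus, strain CD-1) for metabolic stability, read by LC-MS, with a stated time of 60 min, tested at 20 uM (a higher number here means that the compound lasts longer, a lower number that the compound disappears faster), compound 1 `C[C@@H](Sc1nc2c(cnn2C)c(=O)n1-c1ccccc1)c1ccccc1` gives a half-life of 0.133 h and compound 2 `COc1cccc(C(C)Sc2nc3c(cnn3C)c(=O)n2-c2ccccc2)c1` gives 0.1 h on the same read-out. Compound 3 `CC(Sc1nc2c(cnn2C)c(=O)n1-c1ccccc1)c1cccc(F)c1` gives 0.133 h and so stands level with compound 1 at the digits available. All three values lie within the scatter of one another, and no ranking can be drawn from them.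

The next structure is compound 4 `CC(Sc1nc2c(cnn2C)c(=O)n1-c1ccccc1)c1cccc(O)c1`. It carries hydroxy in place of fluoro on an aromatic carbon and the change sits meta to a large group, turning 3-fluorophenyl into 3-hydroxyphenyl.

For the measured compounds named here, two measured steps bear on this place. Going by the values given here, the first is no change at the digits printed from compound 1 to compound 3 (within the scatter) for 1-(3-fluorophenyl)ethyl in place of 1-phenylethyl on a sulfur. The second is a 1.3-fold higher number from compound 2 to compound 3 (0.12 log units; within the scatter) for fluoro in place of methoxy on an aromatic carbon. Among the compounds with values here, both are small, but neither involves hydroxy, and no measured compound here carries that group, so the estimate rests on a narrow base.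

The step expected is a 1.1-fold higher number from compound 3 to compound 4 (0.02 log units; within the scatter) with nothing beyond the scatter anticipated in either direction. Compound 4 is estimated at 0.14 h with an expected range from 0.07 h to 0.3 h for this half-life.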

Compound 4, half-life: 0.0667 h
The estimate for compound 4 lay 2.1-fold (0.32 log units) above the measured number; the whole stated range lies above it.
By their numbers in this assay, from the lowest: compounds 4, 2, 1 and 3 (each within the scatter of the next).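

In this assay the hydroxy group on the aromatic carbon meta to a large group can now be read against three neighbours: against fluoro with a 2.0-fold lower number from compound 3 to compound 4 (0.30 log units; within the scatter) and against methoxy with a 1.5-fold lower number from compound 2 to compound 4 (0.18 log units; within the scatter) and against the plain phenyl of the parent with a 2.0-fold lower number from compound 1 to compound 4 (0.30 log units; within the scatter) on the same read-out. Adding a hydrogen-bond donor at this place therefore gives no step that clears the scatter, and hydrogen, fluoro, methoxy and hydroxy remain unranked here, although the group now differs in kind from the earlier ones. No supporting measurement is available to account for these half-lives.

Whether any group at this place can move the half-life beyond the scatter stays open, and an amine, a carboxylic acid or a longer chain such as ethoxy would each test that in a way the four compounds shown cannot. Also open, going by these compounds, is whether the short half-lives of the series depend on this ring at all or on other parts of the shared core, such as the 1-phenylethyl link on the sulfur.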